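The compounds below may be only part of what the source reports. "The series", "measured", "known", "first", "only" and "open" are said of these compounds alone.

The three measured compounds stand as follows. In an assay on isolated protein for inhibition of vitamin D3 receptor (Homo sapiens), read by fluorescence polarization (a lower number here means a stronger inhibitor, a higher number a weaker inhibitor), compound 1 `CC1CCN(C(=O)CN(C)C(=O)c2ccc(S(C)(=O)=O)c([N+](=O)[O-])c2)CC1` gives > 60000 nM, which is a limit of the assay rather than a number. Compound 2 `CN(Cc1cccc(F)c1)C(=O)CCCNC(=O)c1ccc(S(C)(=O)=O)c([N+](=O)[O-])c1` gives > 60000 nM in this assay, again a limit. Compound 3 `CS(=O)(=O)c1ccc(C(=O)N2CCC(C(=O)N3CCc4ccccc4C3)CC2)cc1[N+](=O)[O-]` gives > 60000 nM in this assay, also a limit.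

Compound 2 therefore stands nowhere apart from the rest: all three sit at the limit of > 60000 nM in this assay, at which 3 of the 3 values shown sit. No step between two measured compounds is shown, so the data give no measured move in this assay from which the weight of any change could be read.

Compound 4 `CN(Cc1ccccc1F)C(=O)CCCNC(=O)c1ccc(S(C)(=O)=O)c([N+](=O)[O-])c1` differs from compound 2 in one place: 2-fluorophenyl in place of 3-fluorophenyl on a saturated chain carbon bound to an amide-type nitrogen. Within the data shown here, with every measured value a limit, there is no step here to suggest that this difference moves the number. The expectation in this assay is a step of no size beyond the scatter, so that compound 4 is expected to stay at the limit, with a step that the limit leaves unreadable from compound 2 to compound 4 as the expected step. Compound 4 is estimated at 100000 nM, in the range 30000 nM to 300000 nM.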

Compound 4, half-maximal inhibitory concentration: > 60000 nM
Compound 4 ended at the assay's limit; the forecaster's own chance of this, stated with the estimate: 85%; the middle value lies beyond the limit too.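

No step can be read between compound 2 and compound 4 in this assay; each gives a limit and not a number: the limit of > 60000 nM in this assay, at which 4 of the 4 values shown sit.

The compounds shown leave open whether 2-fluorophenyl and 3-fluorophenyl differ at all, and whether any change would give a readable number.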